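Compound 4: extending the oxygen substituent

A few compounds are considered here, and "the series" means these few. Any claim that something is new, unique, unknown or untested is made for them only; others in the source may bear on it.

Measured so far:
- compound 1 `CCOC(=O)c1c(C)nc(-c2cccc(C#N)c2)n1O` at 17600 nM
- compound 2 `CCOC(=O)c1c(C)nc(-c2ccccc2C#N)n1OC` at 14900 nM
- compound 3 `CCOC(=O)c1c(C)nc(-c2cccc(C#N)c2)n1OC(C)C` at 6740 nM

In a functional assay on a cell-free system (plasma, Oryctolagus cuniculus) for inhibition, with stated times of 5 min, 1 min and 6 min (a lower number here means a stronger inhibitor, a higher number a weaker inhibitor), compound 1 stands within the scatter of compound 2 and clearly above compound 3 only. Compound 4 `CCOCCOn1c(-c2cccc(C#N)c2)nc(C)c1C(=O)OCC` carries the change 2-ethoxyethyl in place of hydrogen on an oxygen on an aromatic ring on the core of compound 1, that is, 2-ethoxyethyl in place of hydrogen on an oxygen on an aromatic ring. Among the compounds with values here, the one measured step that bears on this is a 2.6-fold lower number from compound 1 to compound 3 (0.42 log units; beyond the scatter) with isopropyl in place of hydrogen, modest but beyond the scatter. Within the data shown here, compound 2 differs from compound 1 in more than one place and gives no clean step. One step is thin support, but a similar modest move to a lower number is expected, estimated as a 2.3-fold lower number from compound 1 to compound 4 (0.37 log units; beyond the scatter) in this assay with wide uncertainty. The estimated value for compound 4 is 7500 nM within a range of 3000 nM to 18000 nM for now.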

Compound 4, half-maximal inhibitory concentration: 6250 nM
For compound 4 the middle estimate is 1.2-fold (0.08 log units) above the measured one, and the stated range covers the measured number.
By their numbers in this assay, from the lowest: compounds 4 and 3 (each within the scatter of the next); then compounds 2 and 1 (each within the scatter of the next).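

In this assay, 2-ethoxyethyl in place of hydrogen on this oxygen gives a 2.8-fold lower number from compound 1 to compound 4 (0.45 log units; beyond the scatter), so a second substituent now moves the number in the same direction as isopropyl. Exchanging isopropyl for 2-ethoxyethyl gives a 1.1-fold lower number from compound 3 to compound 4 (0.03 log units; within the scatter), so the two groups cannot be told apart at this position. No supporting data bear on why these two groups read alike. Open, from the compounds shown here alone, is whether an amine or a carboxylic acid at the end of the chain would shift the number. Also open, going by these compounds, is whether a longer chain would stay level with compound 3 and compound 4.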